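A few compounds are considered here, and "the series" means these few. Any claim that something is new, unique, unknown or untested is made for them only; others in the source may bear on it.

Among the compounds with values here, compound 2 `O=[N+]([O-])c1ccc(N2CCCN(CCC(O)c3csc4ccccc34)CC2)c(C(F)(F)F)c1` and compound 1 `O=C(CCNC1CCN(c2ccc([N+](=O)[O-])cc2C(F)(F)F)CC1)c1csc2ccccc12` are the two measured members of this set. In an assay on HEK293 cells for displacement of a labelled ligand from 5-hydroxytryptamine receptor 7 (Homo sapiens), read by scintillation counting, with a stated time of 1 h (a higher number here means a weaker inhibitor, a lower number a stronger inhibitor), compound 2 gives 8710 nM, the lower of the two numbers, and compound 1 gives 9120 nM; the two values lie within the scatter of each other, so no order between them is claimed. Both are weak. Compound 3 `O=C(CCN1CCCN(c2ccc([N+](=O)[O-])cc2C(F)(F)F)CC1)c1csc2ccccc12` has not yet been tested in this assay. It differs from compound 2 by (1-benzothiophen-3-yl)carbonyl in place of (1-benzothiophen-3-yl)(hydroxy)methyl on a saturated chain carbon, two bonds along the chain from an amine nitrogen in a ring. Within the data shown here, no step between measured compounds that differ in one place is available to set the size of this change. The carbonyl form is present in compound 1, which with a different saturated ring and a different attachment of the chain gives 9120 nM, a weak number like that of compound 2. The step from compound 2 to compound 3 in this assay is therefore expected to be small, in either direction, or none beyond the scatter, as a 1.1-fold lower number from compound 2 to compound 3 (0.04 log units; within the scatter). For compound 3 the expected value in this assay is 8000 nM, with a range from 3000 nM to 25000 nM.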

Compound 3, inhibition constant: > 100000 nM
Compound 3 ended at the assay's limit (the forecaster's own chance of this, stated with the estimate: 10%); middle value at least 12-fold (1.09 log units) away from the limit.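

In this assay, within the data shown here, (1-benzothiophen-3-yl)carbonyl in place of (1-benzothiophen-3-yl)(hydroxy)methyl on a saturated chain carbon, two bonds along the chain from an amine nitrogen in a ring, gives an at least 11-fold higher number from compound 2 to compound 3 (1.05 log units; beyond the scatter) and is the only one-place step. Compounds 1 and 2 differ in more than one place and could not show that this position responds to the change, or that the response can be large. The value of compound 3 is a limit of the assay and not a number: the limit of > 100000 nM in this assay, at which 1 of the 3 values shown sits.

The compounds shown leave open how an amine or a methoxy group on this chain carbon would read, and whether a longer chain would keep the step. They also leave open whether the hydroxy counterpart of compound 1 would differ from compound 1 in the same way.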